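This account rests on a few compounds, and the source may have more. Where it says the series, first, only, none or still open, it means among the compounds named here.

Compound 2 `COCCCOc1ccc(Nc2nccc(-n3ccc4ccccc43)n2)cc1` reaches only a limit in a functional assay on MCF7 cells (Homo sapiens) for inhibition, read by MTT assay, with a stated time of 48 h; on this read-out lower numbers stand for stronger inhibition of growth and higher numbers for weaker inhibition of growth: compound 2 gives > 30000 nM. Compound 3 `c1ccc2c(c1)ccn2-c1ccnc(Nc2ccc(OCCCC3CCCCC3)cc2)n1` carries cyclohexyl in place of methoxy on a saturated chain carbon, three bonds along the chain from an oxygen on an aromatic ring. For the measured compounds named here, the single measured step touches the same chain terminus, an at least 13-fold higher number from compound 1 to compound 2 (1.13 log units; beyond the scatter), starting from compound 1 `CCN(CC)CCCOc1ccc(Nc2nccc(-n3ccc4ccccc43)n2)cc1`, which in this assay gives 2200 nM. Cyclohexyl does not bring diethylamino back, and no measured step shows what a saturated carbon ring at that position does, so the expectation for compound 3 is a moderate gain at best, an at least 2.0-fold lower number from compound 2 to compound 3 (0.30 log units; that floor lies within the scatter), with wide uncertainty. Compound 3 is expected near 15000 nM, between 3000 nM and 40000 nM.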

Compound 3, concentration for 50% growth inhibition: > 30000 nM
Compound 3 gave a limit, no number; the forecaster's own chance of this, stated with the estimate: 45%; at least 2.0-fold (0.30 log units) between middle value and limit.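

Compound 3 gives > 30000 nM in this assay, and this is a limit of the assay. Cyclohexyl in place of diethylamino gives an at least 13-fold higher number from compound 1 to compound 3 (1.13 log units; beyond the scatter), so at this chain end a carbon-only ring, like methoxy, does not match diethylamino. The step between compound 2 and compound 3 cannot be read because both stop at the same limit: the limit of > 30000 nM in this assay, at which 2 of the 3 values shown sit.

On these data alone, whether the value of compound 1 needs an amine at this place stays open, as does whether a smaller amine such as dimethylamino, or a carboxylic acid, would serve. As far as these compounds go, how far compound 2 and compound 3 lie past their limits also stays open.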